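The source may hold more compounds than are shown below. What is called first, only, known or untested is meant among the compounds shown, and "the series" means these compounds.

Compound 1 `CC(O)(COc1ccc(OC(F)(F)F)cc1)C(=O)Nc1cccc(S(F)(F)(F)(F)F)c1` gives 20200 nM
Compound 2 `CC(O)(CS(=O)(=O)c1cccc(S(F)(F)(F)(F)F)c1)C(=O)Nc1ccc(S(F)(F)(F)(F)F)cc1` gives 24800 nM

In a functional assay on VCaP cells (Homo sapiens) for antiproliferative activity, read by propidium iodide staining, with a stated time of 96 h (a lower number here means a stronger inhibitor, a higher number a weaker inhibitor), compound 2 gives 24800 nM and so stands level with compound 1 within the scatter of repeated measurements. Compound 3 `CC(O)(CS(=O)(=O)c1cccc(OC(F)(F)F)c1)C(=O)Nc1ccc(S(F)(F)(F)(F)F)cc1` is compound 2 with a single swap on an aromatic carbon, meta to a large group: a group of 5 heavy atoms (1 carbon, 1 oxygen, 3 fluorine; no ring) in place of a group of 6 heavy atoms (5 fluorine, 1 sulfur; no ring), on an aromatic carbon is the whole change. For the measured compounds named here, no measured pair of compounds shows this swap alone. In this assay no step beyond the scatter is expected, in either direction. The estimated move is a 1.2-fold lower number from compound 2 to compound 3 (0.09 log units; within the scatter) and it stays inside that scatter. Compound 3 is estimated at 20000 nM (8000 nM to 40000 nM).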

Compound 3, half-maximal inhibitory concentration: 23700 nM
Compound 3: the middle estimate sits 1.2-fold (0.07 log units) below what was measured; the measured number falls inside the stated range.
By their numbers in this assay, from the lowest: compounds 1, 3 and 2 (each within the scatter of the next).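

Placing trifluoromethoxy on this aromatic carbon, in place of the group of 5 fluorine atoms and 1 sulfur, gives a 1.0-fold lower number from compound 2 to compound 3 (0.02 log units; within the scatter) in this assay and this is the first comparison here between compounds that differ in one place. At this position, the two groups cannot be told apart in this assay. No measurement shown here explains this result.

Going by these compounds, what an amine or a carboxylic acid on this carbon would do remains open. So does whether any group here can move the number beyond the scatter.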